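The compounds below may be only part of what the source reports. "The series", "measured", "known", "first", "only" and "open" are said of these compounds alone.

Measured compounds:
- Compound 1, `CCC(=O)N1N=C(C)CC1c1cc(Br)ccc1O`: 50300 nM
- Compound 2, `Cc1ccc(C(=O)N2N=C(c3cc4ccccc4oc3=O)CC2c2ccccc2)cc1`: 31300 nM
- Compound 3, `CC(C)(C)OC(=O)N1CCN(CC(=O)N2N=C(c3cc4ccccc4oc3=O)CC2c2ccccc2)CC1`: "not active" (no number reported)

In a functional assay on MGC-803 cells (Homo sapiens) for cytotoxicity, read by MTT assay, with a stated time of 48 h (a lower number here means a stronger inhibitor, a higher number a weaker inhibitor), compound 2 gives 31300 nM and compound 1 gives 50300 nM; the two numbers lie within the usual scatter of each other, so neither can be ranked ahead of the other. Compound 3 shares the core of compound 2 but carries a different group on the carbonyl carbon and is reported as not active, with no number attached.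

Compound 4, `NC(=O)C1CCN(CC(=O)N2N=C(c3cc4ccccc4oc3=O)CC2c2ccccc2)CC1`, has not yet been measured in this assay. It differs from compound 2 in one place: (4-carbamoylpiperidin-1-yl)methyl in place of 4-methylphenyl on a carbonyl carbon. Going by the values given here, no measured pair in this set shows exactly such a step, so its size can only be expected, not read off. Among the compounds with values here, the group that enters in compound 4 is closer in kind to the group carried by compound 3 than to the one carried by compound 2, and compound 3 gave no measurable number. Compound 4 is therefore expected to come out weaker than compound 2, with an expected step of a 2.2-fold higher number from compound 2 to compound 4 (0.35 log units; beyond the scatter), though a number within the scatter is not ruled out. Compound 4 is estimated at 70000 nM, in a range from 25000 nM to 250000 nM, with a real chance that the assay returns no number at all.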

Compound 4, half-maximal inhibitory concentration: 21500 nM
The estimate for compound 4 lay 3.3-fold (0.51 log units) above the measured number; measured number outside the range, below it.
By their numbers in this assay, from the lowest: compounds 4, 2 and 1 (each within the scatter of the next, the first and the last beyond it).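

In this assay, going by these compounds alone, the exchange of 4-methylphenyl for (4-carbamoylpiperidin-1-yl)methyl on this carbonyl carbon gives a 1.5-fold lower number from compound 2 to compound 4 (0.16 log units; within the scatter) and so cannot be told apart from no step at all. This position therefore accepts a non-aromatic ring with a hetero atom in place of an aromatic ring of carbon only and still returns a number, so losing the 4-methylphenyl cannot alone account for the not-active report on compound 3. Nothing in the data shown explains this result.

On these data alone, it remains open whether the carbamoyl group of compound 4 contributes anything, since no plain piperidin-1-ylmethyl group stands beside it. Also open, as far as these compounds go, is whether a carboxylic acid or a primary amine in its place would keep a measurable number.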